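The compounds below may be only part of what the source reports. "The series", "measured", "known", "first", "only" and "open" are said of these compounds alone.

Compound 2 `Nc1nc(-c2cnco2)nc2sc(Cc3ccccc3)cc12` gives the lower of the two numbers recorded so far in a functional assay on CHO-K1 cells for antagonist activity at adenosine receptor A1 (Homo sapiens), read by a beta-galactosidase reporter and cAMP accumulation, with stated times of 15 min and 6 h; a higher number here means a weaker inhibitor, a lower number a stronger inhibitor. Among the compounds with values here, its one neighbour, compound 1 `CC(C)c1ccc(-c2nc(N)c3cc(Cc4ccccc4)sc3n2)o1`, gives 283 nM in this assay, while compound 2 gives 106 nM. Within the data shown here, the one step recorded between them, a 2.7-fold lower number from compound 1 to compound 2 (0.43 log units; beyond the scatter), is the only measured change at the shared core.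

Compound 3 `N#Cc1cccc(-c2nc(N)c3cc(Cc4ccccc4)sc3n2)c1` differs from compound 2 in a single place: 3-cyanophenyl in place of 1,3-oxazol-5-yl on an aromatic carbon. The step from compound 1 to compound 2 touches the same position, but swaps a different pair of groups, so it bears on compound 3 only loosely. It shows that a change of the group at this position moves the number modestly, not greatly. A six-membered carbon ring with a nitrile enters where a small five-membered ring with two hetero atoms leaves, so the author expects a modest rise in this assay from compound 2 to compound 3, of about a 1.9-fold higher number from compound 2 to compound 3 (0.28 log units; within the scatter), and certainly not a step far beyond the scatter. Compound 3 is therefore estimated at 200 nM in this assay, within a range from 60 nM to 650 nM.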

Compound 3, inhibition constant: 222 nM
For compound 3 the middle estimate is 1.1-fold (0.05 log units) below the measured one, and the stated range covers the measured number.
By their numbers in this assay, from the lowest: compound 2; then compounds 3 and 1 (each within the scatter of the next).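

In this assay, replacing 1,3-oxazol-5-yl with 3-cyanophenyl on the same aromatic carbon, between two ring nitrogen atoms, gives a 2.1-fold higher number from compound 2 to compound 3 (0.32 log units; beyond the scatter) and so moves the number only modestly, even though the six-membered aromatic ring of carbon only brings more heavy atoms and a nitrile. The comparison with the other group at this position gives a 1.3-fold lower number from compound 1 to compound 3 (0.11 log units; within the scatter), so 3-cyanophenyl and 5-isopropylfuran-2-yl cannot be told apart here, and of the three groups only 1,3-oxazol-5-yl stands apart, with steps beyond the scatter to both others. Nothing measured in this account bears on why the number shifts with these groups.

The compounds shown leave open whether the nitrile contributes at all, which a plain phenyl ring or a 4-cyanophenyl group at this position would test. They also leave open whether the lower number of compound 2 is particular to 1,3-oxazol-5-yl or extends to other five-membered rings, such as a thiazole or an imidazole.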